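A Ring One Atom Larger at the Edge of Detection

A few compounds are considered here, and "the series" means these few. Any claim that something is new, unique, unknown or untested is made for them only; others in the source may bear on it.

Compound 1 `O=C(O)Cc1sc(C(c2ccc(F)cc2)c2ccc(F)cc2)nc1-c1ccc(Cl)cc1` and compound 2 `O=C(O)Cc1sc(C(c2ccc(F)cc2)c2ccc(F)cc2)nc1-c1cccc(F)c1` share their core with compound 3 `O=C(O)Cc1sc(C(c2ccc(F)cc2)c2ccc(F)cc2)nc1-c1ccnc(N2CCC2)c1`, which carries a 2-(azetidin-1-yl)pyridin-4-yl group where the others carry a halogenated phenyl. In an in vitro functional assay on HEK285-7 cells for antagonist activity at prostaglandin D2 receptor 2 (Homo sapiens), read by BRET and beta-arrestin recruitment (on this read-out lower numbers stand for stronger inhibition and higher numbers for weaker inhibition), compound 1 gives 180 nM and compound 2 gives 18 nM. Compound 3 is reported only as a limit of the assay, > 100000 nM, the level described as the limit of > 100000 nM in this assay, at which 1 of the 3 values shown sits. The steps of an at least 550-fold higher number from compound 1 to compound 3 (2.74 log units; beyond the scatter) and an at least 5500-fold higher number from compound 2 to compound 3 (3.74 log units; beyond the scatter) are both large. Compound 4 `O=C(O)Cc1sc(C(c2ccc(F)cc2)c2ccc(F)cc2)nc1-c1ccnc(N2CCCC2)c1` differs from compound 3 by pyrrolidin-1-yl in place of azetidin-1-yl on an aromatic carbon. For the measured compounds named here, no measured step alters this ring on its own, so the expectation rests on compound 3 sitting at the limit. The step that the limit leaves unreadable from compound 3 to compound 4 is therefore expected to be none beyond the scatter. Compound 4 is estimated at 150000 nM, between 30000 nM and 1000000 nM.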

Compound 4, half-maximal inhibitory concentration: > 100000 nM
Compound 4: only a limit was reported (the forecaster's own chance of this, stated with the estimate: 80%); the middle value does not contradict the limit.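

Pyrrolidin-1-yl in place of azetidin-1-yl leaves the pyridine compound still at the limit in this assay, so the loss is not peculiar to the four-membered ring: the limit of > 100000 nM in this assay, at which 2 of the 4 values shown sit.

Against the halogenated phenyl compounds, the new group gives an at least 5500-fold higher number from compound 2 to compound 4 (3.74 log units; beyond the scatter) and an at least 550-fold higher number from compound 1 to compound 4 (2.74 log units; beyond the scatter). The step between the two ring sizes cannot be read, since both values are limits.

The compounds shown do not separate the contribution of the pyridine ring nitrogen from that of the saturated ring. Going by these compounds, whether a plain pyridin-4-yl or a methoxy group on that carbon would return within range remains open.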